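Azetidine hydroxy removal on the shared core

The source may hold more compounds than are shown below. What is called first, only, known or untested is meant among the compounds shown, and "the series" means these compounds.

Measured so far in a functional assay on NCI-H146 cells (Homo sapiens) for inhibition, read by WST assay, with a stated time of 4 days; a lower number here means a stronger inhibitor, a higher number a weaker inhibitor:
compound 1 `Cc1c(C(=O)O)c(-c2cccc(N3CCN(c4ccc(NS(=O)(=O)c5ccc(N[C@H](CCN6CC(O)C6)CSc6ccccc6)c(S(=O)(=O)C(F)(F)F)c5)cc4)CC3)c2)c(-c2ccc(Cl)cc2)n1C` gives 241 nM;
compound 2 `CCCCn1c(C)c(C(=O)O)c(-c2cccc(N3CCN(c4ccc(NS(=O)(=O)c5ccc(N[C@H](CCN6CCC(O)CC6)CSc6ccccc6)c(S(=O)(=O)C(F)(F)F)c5)cc4)CC3)c2)c1-c1ccc(Cl)cc1` gives 128 nM;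
compound 3 `Cc1c(C(=O)O)c(-c2cccc(N3CCN(c4ccc(NS(=O)(=O)c5ccc(N[C@H](CCN6CCC(O)CC6)CSc6ccccc6)c(S(=O)(=O)C(F)(F)F)c5)cc4)CC3)c2)c(-c2ccc(Cl)cc2)n1C(C)C` gives 13 nM.

Compound 1 has the highest number of the three in this assay. Against compound 2 the gap is within the scatter, so no order between them is claimed. Against compound 3 the gap is beyond the scatter; compound 3 differs in more than one place, so no single change accounts for it.

Compound 4 `Cc1c(C(=O)O)c(-c2cccc(N3CCN(c4ccc(NS(=O)(=O)c5ccc(N[C@H](CCN6CCC6)CSc6ccccc6)c(S(=O)(=O)C(F)(F)F)c5)cc4)CC3)c2)c(-c2ccc(Cl)cc2)n1C` is not yet measured. It differs from compound 1 by hydrogen in place of hydroxy on a saturated ring carbon, in words: hydrogen in place of hydroxy on a saturated ring carbon. For the measured compounds named here, no pair among the measured compounds isolates this change, so the expectation rests on compound 1 alone. The step from compound 1 to compound 4 in this assay is expected to be small, around or within the scatter, with a slight lean toward a higher number, as a 1.3-fold higher number from compound 1 to compound 4 (0.12 log units; within the scatter). Compound 4 is therefore estimated at 320 nM, within a range from 110 nM to 950 nM.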

Compound 4, half-maximal inhibitory concentration: 86 nM
The estimate for compound 4 lay 3.7-fold (0.57 log units) above the measured number; the whole stated range lies above it.
By their numbers in this assay, from the lowest: compound 3; then compounds 4, 2 and 1 (each within the scatter of the next, the first and the last beyond it).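

Taking 3-hydroxyazetidin-1-yl to azetidin-1-yl on the shared core gives a 2.8-fold lower number from compound 1 to compound 4 (0.45 log units; beyond the scatter) in this assay, a modest step and the first that isolates this change. At this position, two ring bonds from the ring nitrogen, the hydroxy is therefore not required for activity in this assay, and hydrogen in its place gives the lower number. Nothing on hand explains the step, and no measurement bears on its origin.

As far as these compounds go, whether a fluorine, a methoxy or an amino group on that same saturated ring carbon would read closer to compound 1 or to compound 4 remains open. Also open, from the compounds shown here alone, is whether hydrogen in place of hydroxy gives a step of similar size on the hydroxy-bearing ring of compound 3.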